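A few compounds are considered here, and "the series" means these few. Any claim that something is new, unique, unknown or untested is made for them only; others in the source may bear on it.

Measured compounds:
- Compound 1, `CN(C)CCC(OC(=O)NCc1ccccc1)c1ccc(Cl)cc1`, in an assay on NIH3T3 cells with Urotensin-2 receptor (Homo sapiens) as the target (a higher number here means a larger maximal response, a lower number a smaller maximal response), gives 180%.
- Compound 2, `COc1cccc(NC(=O)OC(CCN(C)C)c2ccc(Cl)cc2)c1`, in this assay gives 136%.
- Compound 3, `CN(C)CCC(NC(=O)NCc1ccccc1)c1ccc(Cl)cc1`, in this assay gives 179%.

Compound 1 and compound 3 carry different cores; the difference between the two cores is not broken down here. Their values in this assay lie within the scatter of one another, while compound 2 stands apart from both.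

For the measured compounds named here, the one counted change is 3-methoxyphenyl in place of benzyl on an amide-type nitrogen. It made a number 44 percentage points lower from compound 1 to compound 2 (beyond the scatter).

Compound 4, `COc1cccc(NC(=O)NC(CCN(C)C)c2ccc(Cl)cc2)c1`, is not yet measured. It arises from compound 3 by the same change, (3-methoxyphenyl in place of benzyl on an amide-type nitrogen), made on the core of compound 3. The two changes sit on the same kind of nitrogen with the same neighbour, so the step from compound 3 to compound 4 in this assay is expected to resemble the earlier one, because compound 1 to compound 2 gave a number 44 percentage points lower from compound 1 to compound 2 (beyond the scatter). Since compound 3 starts from 179%, close to compound 1, the expected step is a number 44 percentage points lower from compound 3 to compound 4 (beyond the scatter). For compound 4 the estimate in this assay is 135%, with a range from 110% to 160%.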

Compound 4, largest response reached (reported as efficacy), in percent of the reference or control that the assay uses: 146%
Beside the measured number, compound 4's estimate is 11 percentage points below it; low and high end bracket the measured number.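

In this assay, 3-methoxyphenyl in place of benzyl on an amide-type nitrogen gave a number 33 percentage points lower from compound 3 to compound 4 (beyond the scatter). The change therefore carries over from the core of compound 1 to the core of compound 3 in direction, and the two steps do not differ in size beyond the scatter: the same change on two cores in this assay, a number 44 percentage points lower (beyond the scatter) from compound 1 to compound 2 and a number 33 percentage points lower (beyond the scatter) from compound 3 to compound 4, 11 percentage points apart, within the scatter of two such steps. This rests on two pairs on two cores only, so it shows no general rule for other cores or other groups on this nitrogen, and it gives no reason for the lower maximal response.

The compounds shown leave open how much of the step belongs to the methoxy group and how much to the loss of benzyl, a question that plain phenyl on the same nitrogen would address. They also leave open how 3-methoxybenzyl or a longer chain such as 2-phenylethyl would behave on either core.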